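The source may report more compounds than this note shows. Statements on the series, on what has been measured and on what is new or still open speak of the compounds shown alone.

Measured compounds:
compound 1, `N#C/C(=C\c1c(-c2ccccc2)[nH]c2ccccc12)C(=O)c1cccs1`, 6400 nM
compound 2, `COc1ccc2[nH]c(-c3ccccc3)c(/C=C(\C#N)S(=O)(=O)c3ccccc3)c2c1`, 2800 nM
compound 3, `O=C(/C(=C\c1c(-c2ccccc2)[nH]c2ccccc12)C(=O)C(F)(F)F)c1ccco1`, 2300 nM

Of the compounds shown here, three built on a shared core have been tested in a functional assay on WIL2-NS cells (Homo sapiens) for cytotoxicity, read by MTT assay, with a stated time of 96 h; on this read-out higher numbers stand for an effect only at larger amounts of compound and lower numbers for an effect already at smaller amounts. Compound 1 gives the highest of the three numbers, 6400 nM. Compound 2 gives 2800 nM, a number that lies below that of compound 1 by a margin beyond the usual scatter. Compound 3 gives 2300 nM, the lowest of the three, and its gap to compound 1 is likewise beyond the scatter. Compound 1 therefore stands alone at the high end of this small set.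

Compound 4, `N#C/C(=C\c1c(-c2ccccc2)[nH]c2ccccc12)C(=O)c1ccc(Cl)cc1`, has not yet been measured in this assay. It differs from compound 1 in a single place: 4-chlorophenyl in place of thiophen-2-yl on a carbonyl carbon. Among the measured compounds shown here, no pair of measured compounds differs in only this way, so the size of this step cannot be read from any measured pair; compound 2 and compound 3 each differ from compound 1 in more than one place. With no such comparison to lean on, the change is expected to move the number only modestly, if at all. Compound 4 is expected to give 4500 nM, within a range from 1500 nM to 15000 nM. The expected step, a 1.4-fold lower number from compound 1 to compound 4 (0.15 log units; within the scatter), points slightly downward and may well stay within the scatter.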

Compound 4, half-maximal effective concentration: 4500 nM
Estimate against measurement, compound 4: no gap at the digits printed, and the stated range covers the measured number.
By their numbers in this assay, from the lowest: compounds 3, 2, 4 and 1 (each within the scatter of the next, the first and the last beyond it).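

In this assay, among the compounds shown here, 4-chlorophenyl in place of thiophen-2-yl on a carbonyl carbon gives a 1.4-fold lower number from compound 1 to compound 4 (0.15 log units; within the scatter), the first step in this set that can be read at a single place. At this position, a six-membered aromatic ring of carbon only, carrying chlorine, therefore cannot be told apart on this read-out from a five-membered aromatic ring with a sulfur hetero atom, even though the entering group is the larger by heavy-atom count. Nothing measured on either group bears on this result.

The compounds shown leave open whether the number at this position would stay as it is with a group of another kind, such as a simple amine, a carboxylic acid or a longer alkyl chain, or whether the chlorine itself matters, which unsubstituted phenyl would address. Going by these compounds, compound 2 and compound 3 each differ from compound 1 in more than one place, so their steps cannot be read, and the other parts of the shared core remain untested one place at a time.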